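Cyclopentyl in place of ethyl at the ketone side chain

This account rests on a few compounds, and the source may have more. Where it says the series, first, only, none or still open, it means among the compounds named here.

Among the compounds with values here, compound 3 `CCCC(=O)c1ccc(OCCCCOc2cc(C(=O)O)ccc2OC)c(C)c1O` holds the lowest of the two numbers so far in an assay on HEK293 cells for positive allosteric modulation of metabotropic glutamate receptor 3 (Rattus norvegicus), read by thallium flux, with a stated time of 2.5 min; on this read-out higher numbers stand for an effect only at larger amounts of compound and lower numbers for an effect already at smaller amounts; compound 3 gives 496 nM. The nearest measured neighbour is compound 1 `Cc1c(OCCCCOc2ccc(F)c(C(=O)O)c2)ccc(C(=O)CC2CCCC2)c1O`, which in this assay gives 2490 nM, a higher number that lies beyond the scatter. Compound 2 `Cc1c(OCCCCOc2ccc(C(=O)O)cc2)ccc(C(=O)CC2CCCC2)c1O` reaches only a limit of this assay, where compound 2 gives > 10000 nM. Within the data shown here, the single measured step, an at least 4.0-fold higher number from compound 1 to compound 2 (0.60 log units; beyond the scatter), concerns the aryl carboxylic acid on an oxygen on a saturated carbon and runs into (the limit of > 10000 nM in this assay, at which 1 of the 3 values shown sits); it says nothing about the ketone side chain.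

Compound 4 `COc1ccc(C(=O)O)cc1OCCCCOc1ccc(C(=O)CC2CCCC2)c(O)c1C` differs from compound 3 by cyclopentyl in place of ethyl on a saturated chain carbon bound to a carbonyl carbon. Cut one bond further out, the propylcarbonyl of compound 3 becomes the (cyclopentylmethyl)carbonyl that compound 1 already carries, but compound 1 also bears a different aryl acid, so its value of 2490 nM does not isolate this change. Among the measured compounds shown here, no measured step bears on the swap of ethyl for cyclopentyl, so the expected step in this assay is none beyond the scatter, written as a 1.2-fold higher number from compound 3 to compound 4 (0.08 log units; within the scatter). Compound 4 is therefore estimated at 600 nM in this assay, with a range from 150 nM to 2500 nM.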

Compound 4, half-maximal effective concentration: 1020 nM
For compound 4 the middle estimate is 1.7-fold (0.23 log units) below the measured one; low and high end bracket the measured number.
By their numbers in this assay, from the lowest: compound 3; then compound 4; then compound 1. At a limit, above all of these: compound 2.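

The ketone side chain now has a measured step of its own in this assay: cyclopentyl in place of ethyl on a saturated chain carbon bound to a carbonyl carbon gives a 2.1-fold higher number from compound 3 to compound 4 (0.31 log units; beyond the scatter), so with the 5-carboxy-2-methoxyphenyl group held fixed, the propylcarbonyl of compound 3 gives the lower number. With the (cyclopentylmethyl)carbonyl held fixed, the aryl acid now has a second measured step, as 5-carboxy-2-methoxyphenyl in place of 3-carboxy-4-fluorophenyl gives a 2.4-fold lower number from compound 1 to compound 4 (0.39 log units; beyond the scatter). The same group in place of 4-carboxyphenyl gives an at least 9.8-fold lower number from compound 2 to compound 4 (0.99 log units; beyond the scatter), and the size of this step is only a bound, since compound 2 stands at a limit and not at a number: the limit of > 10000 nM in this assay, at which 1 of the 4 values shown sits.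

As far as these compounds go, the cyclopentyl step is read with a single aryl acid, so it stays open whether it keeps its direction or size with 3-carboxy-4-fluorophenyl or 4-carboxyphenyl. Also open, from the compounds shown here alone, is how the ketone side chain responds to a phenyl or cyclohexyl at the same place, or to a longer straight chain such as pentyl in place of the ethyl.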